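Nitro substitution on a thiosemicarbazone at the assay limit

The source may hold more compounds than are shown below. What is called first, only, known or untested is meant among the compounds shown, and "the series" means these compounds.

Compound 1 `CC1=CC[C@H](C(C)(C)NC(=S)N/N=C/c2ccccc2)CC1`: 20500 nM
Compound 2 `CC1=CC[C@H](C(C)(C)NC(=S)N/N=C(\C)c2ccccc2)CC1`: > 100000 nM, a limit only

In an ADME assay on Vero cells (Chlorocebus sabaeus) for inhibition, read by sulforhodamine B assay, with a stated time of 48 h (on this read-out lower numbers stand for stronger inhibition of growth and higher numbers for weaker inhibition of growth), compound 1 gives 20500 nM. For compound 2 the read-out is only a limit of the assay, > 100000 nM. Compound 2 therefore stands at the limit of > 100000 nM in this assay, at which 1 of the 2 values shown sits. Compound 3 `CC1=CC[C@H](C(C)(C)NC(=S)N/N=C(\C)c2ccc([N+](=O)[O-])cc2)CC1` differs from compound 2 by nitro in place of hydrogen on an aromatic carbon. Going by the values given here, no step between measured compounds is available, so the size of this change on this assay cannot be read from the data; the expectation is that the nitro compound stays near the limit, with no step beyond the scatter. Compound 3 is accordingly estimated at 100000 nM, between 30000 nM and 300000 nM, which corresponds to an expected step of a number no higher from compound 2 to compound 3 (the limit leaves the size open).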

Compound 3, concentration for 50% growth inhibition: 67100 nM
For compound 3 the middle estimate is 1.5-fold (0.17 log units) above the measured one; low and high end bracket the measured number.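

In this assay, nitro in place of hydrogen on an aromatic carbon, para to a large group, gives an at least 1.4-fold lower number from compound 2 to compound 3 (0.17 log units; that floor lies within the scatter). As far as these compounds go, this places compound 3 on a measured number, so the change can at least be read in one direction, although its true size stays unknown. The reading for compound 2 is only a limit: the limit of > 100000 nM in this assay, at which 1 of the 3 values shown sits.

The compounds shown leave open whether an amine or a carboxylic acid on the same aromatic carbon would shift the read-out as nitro does. They also leave open whether nitro gives a similar step on compound 1.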